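This account rests on a few compounds, and the source may have more. Where it says the series, first, only, none or still open, it means among the compounds named here.

Working notes on the series. In a functional assay on A549 cells (Homo sapiens) for inhibition, read by MTT assay, with a stated time of 72 h (on this read-out lower numbers stand for stronger inhibition and higher numbers for weaker inhibition), compound 1 (`CC/C=C\C(=O)Nc1cc(Nc2nc3c(c(-c4cn(C)c5ccc(F)cc45)n2)CSCC3)c(OC)cc1N(C)CCN(C)C`) gives 1450 nM and compound 2 (`C=CC(=O)Nc1cc(Nc2nc3c(c(-c4cn(C)c5ccccc45)n2)CS(=O)(=O)CC3)c(OC)cc1N(C)CCN(C)C`) gives 8690 nM. Compound 2 therefore holds the higher of the two numbers, and the gap lies beyond the scatter. Compound 1 differs from compound 2 in more than one place, so this gap gives no size for any single change.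

The next entry is compound 3 (`C/C=C\C(=O)Nc1cc(Nc2nc3c(c(-c4cn(C)c5ccccc45)n2)CS(=O)(=O)CC3)c(OC)cc1N(C)CCN(C)C`), which carries prop-1-en-1-yl in place of vinyl on a carbonyl carbon. Among the compounds with values here, no measured pair isolates this change, so the expectation is cautious and has no firm direction. The expected move in this assay, a 1.2-fold lower number from compound 2 to compound 3 (0.09 log units; within the scatter), stays within the scatter. For compound 3 the estimated value is 7000 nM, with an expected range of 2500 nM to 20000 nM.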

Compound 3, half-maximal inhibitory concentration: 4260 nM
Beside the measured number, compound 3's estimate is 1.6-fold (0.22 log units) above it; the measured number falls inside the stated range.
By their numbers in this assay, from the lowest: compound 1; then compound 3; then compound 2.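

In this assay the exchange of vinyl for prop-1-en-1-yl on a carbonyl carbon gives a 2.0-fold lower number from compound 2 to compound 3 (0.31 log units; beyond the scatter), the first size in the series for a single change. At this place, whose other carbonyl neighbour is an amide-type nitrogen, the group with 3 heavy atoms therefore gives a modest gain over the group with 2, with the double bond outside aromatic rings kept and no hydrogen-bond donor or acceptor added. Nothing measured here accounts for the step.

Going by these compounds, whether a saturated ethyl group or a chain carrying an amine at this carbonyl carbon would move the number further remains open. Also open, on these data alone, is whether the same step would hold on the core of compound 1, which differs from compound 2 in more than one place.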